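The compounds below may be only part of what the source reports. "The series", "measured", "known", "first", "only" and "open" are said of these compounds alone.

Three compounds have been measured in an ADME assay on A549 cells (Homo sapiens) for cytotoxicity, read by MTT assay, with a stated time of 48 h; on this read-out higher numbers stand for weaker inhibition of growth and lower numbers for stronger inhibition of growth:

compound 1 `O=C(/C=C\c1ccccc1O)N1N=C(c2ccncc2)OC1c1c[nH]c2ccccc12`: > 30 ug/mL, a limit of the assay and not a number
compound 2 `O=C(/C=C\c1ccc(O)cc1)N1N=C(c2ccncc2)OC1c1c[nH]c2ccccc12`: > 30 ug/mL, a limit of the assay and not a number
compound 3 `O=C(/C=C\c1cccc([N+](=O)[O-])c1)N1N=C(c2ccncc2)OC1c1c[nH]c2ccccc12`: > 30 ug/mL, a limit of the assay and not a number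

Compound 2 therefore stands at the same limit as the other two, and the limit of > 30 ug/mL in this assay, at which 3 of the 3 values shown sit, shows that no measured value in this set is a number at all. The steps among them, a step that the two limits leave unreadable from compound 1 to compound 2, a step that the two limits leave unreadable from compound 1 to compound 3 and a step that the two limits leave unreadable from compound 2 to compound 3, cannot be read for size because both ends of each step are limits.

Compound 4 `O=C(/C=C\c1ccc(F)cc1)N1N=C(c2ccncc2)OC1c1c[nH]c2ccccc12` differs from compound 2 by fluoro in place of hydroxy on an aromatic carbon. Going by the values given here, none of the measured steps gives a readable size, so nothing here says that this change would move the read-out in either direction beyond the scatter. The expectation for compound 4 is that it, too, will sit at or beyond the limit, with an estimated value of 40 ug/mL (range 20 ug/mL to 100 ug/mL), which would mean an expected step that the limit leaves unreadable from compound 2 to compound 4 from compound 2.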

Compound 4, concentration for 50% growth inhibition: > 30 ug/mL
Compound 4: a limit, no number; the forecaster's own chance of this, stated with the estimate: 80%; the middle value lies beyond the limit too.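

Compound 4 gives a limit and not a number, as do compound 1, compound 2 and compound 3, so no step among these four compounds can be read: the limit of > 30 ug/mL in this assay, at which 4 of the 4 values shown sit.

The compounds shown leave open whether any of these groups on the shared core would give a true number in this assay.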